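Triazolopyridazine thioethers: aryl swap at the triazole carbon

A few compounds are considered here, and "the series" means these few. Any claim that something is new, unique, unknown or untested is made for them only; others in the source may bear on it.

The series shares the core seen in compound 1 `COc1ccc(OC)c(Sc2ccc3nnc(-c4ccccn4)n3n2)c1`, which in an assay on HEK293 cells for inhibition of Leucine-rich repeat serine/threonine-protein kinase 2 (Homo sapiens), read by ELISA, with a stated time of 90 min (on this read-out lower numbers stand for stronger inhibition and higher numbers for weaker inhibition), gives 1310 nM. Compound 2 `COc1ccc(OC)c(Sc2ccc3nnc(-c4ccncc4)n3n2)c1` carries a pyridin-4-yl on the same carbon; in this assay compound 2 has an entry of "not determined" (no result reported), so no number is available for it. Compound 3 `COc1ccc(OC)c(Sc2ccc3nnc(C4CCN(C)C4)n3n2)c1` replaces the aromatic substituent with a saturated amine; in this assay compound 3 likewise stands at "not determined" (no result reported), which gives no single number, and one further member of the set, compound 2, is in the same position. Compound 3 therefore cannot be placed against compound 1 on the numbers shown.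

Compound 4 `COc1ccc(OC)c(Sc2ccc3nnc(-c4ccsn4)n3n2)c1` is reached from compound 3 by one change: 1,2-thiazol-3-yl in place of 1-methylpyrrolidin-3-yl on an aromatic carbon. Among the compounds with values here, no step between measured compounds is on record, so the size and direction of this move are unknown; it brings back an aromatic five-membered ring with a ring nitrogen at the attachment carbon, which makes compound 1 the nearest measured reference point rather than compound 3. The expectation is therefore anchored on compound 1, with a wide allowance for the unknown. In this assay compound 4 is estimated at 1500 nM, within a range of 400 nM to 6000 nM.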

Compound 4, half-maximal inhibitory concentration: 722 nM
For compound 4 the middle estimate is 2.1-fold (0.32 log units) above the measured one; the measured number falls inside the stated range.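

In this assay, within the data shown here, the swap of pyridin-2-yl for 1,2-thiazol-3-yl gives a 1.8-fold lower number from compound 1 to compound 4 (0.26 log units; within the scatter), the first step at this carbon with a number on both sides. The position therefore accepts a five-membered aromatic ring with 2 hetero atoms in place of pyridin-2-yl without a difference beyond the usual scatter, so the two compounds cannot be ranked against each other. Compound 2 and compound 3 have no number, so any step involving them cannot be read, and neither the pyridin-4-yl nor the 1-methylpyrrolidin-3-yl group can be placed relative to compound 4; nothing on record bears on the reason for the close agreement between the two measured compounds.

Still open, from the compounds shown here alone, is whether a different kind of group on this carbon, such as a primary amine, a carboxylic acid or a plain phenyl ring, would move the number beyond the scatter. Also open, going by these compounds, is whether the agreement between pyridin-2-yl and 1,2-thiazol-3-yl would hold if the two methoxy groups elsewhere on the shared core gave way to chlorine atoms.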